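Urea aryl variation on a pyrazole series in kidney cells

This account rests on a few compounds, and the source may have more. Where it says the series, first, only, none or still open, it means among the compounds named here.

Measured compounds:
- compound 1, `COc1cc(Cl)cc(-c2nn(-c3cccc(NC(=O)Nc4ccc(Cl)c(C(F)(F)F)c4)c3)cc2-c2ccncc2)c1`, -50%
- compound 2, `COc1cc(Cl)cc(-c2nn(-c3cccc(NC(=O)Nc4cc(C(F)(F)F)cc(C(F)(F)F)c4)c3)cc2-c2ccncc2)c1`, -82%
- compound 3, `COc1cc(Cl)cc(-c2nn(-c3cccc(NC(=O)Nc4ccc(Cl)c(Cl)c4)c3)cc2-c2ccncc2)c1`, -10%

In a functional assay on UO-31 cells (Homo sapiens) for inhibition, read by sulforhodamine B assay, with a stated time of 48 h, tested at 100 uM (on this read-out lower numbers stand for a stronger effect and higher numbers for a weaker effect at the one concentration tested), compound 3 stands highest of the three numbers, meaning the weakest effect of the set; compound 1 lies closest, and compound 2 furthest away. Compound 4, `COc1cc(Cl)cc(-c2nn(-c3cccc(NC(=O)Nc4cccc(C(F)(F)F)c4)c3)cc2-c2ccncc2)c1`, has not yet been measured. It differs from compound 3 in the aryl group carried on the urea: 3-(trifluoromethyl)phenyl in place of 3,4-dichlorophenyl on an amide-type nitrogen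

For the measured compounds named here, only one measured step touches this part of the molecule. From compound 1 to compound 3 a single trifluoromethyl was exchanged for a chloro, and the number rose: a number 40 percentage points higher from compound 1 to compound 3 (beyond the scatter). The change to compound 4 runs the other way in part, bringing a trifluoromethyl back in, but it also takes away the second chloro, so the two measured neighbours do not cover it exactly. Compound 2, with two trifluoromethyl groups, gives the lowest number of all, which points in the same direction.

On that basis compound 4 is expected to give a lower number than compound 3, a step of about a number 25 percentage points lower from compound 3 to compound 4 (beyond the scatter) in this assay, with the estimate for compound 4 at -35% and a likely range from -70% to 0%.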

Compound 4, a percentage reported as activity, at one concentration (the size of the read-out at that concentration, not a potency): -20%
For compound 4 the middle estimate is 15 percentage points below the measured one; low and high end bracket the measured number.
By their numbers in this assay, from the lowest: compound 2; then compound 1; then compounds 4 and 3 (each within the scatter of the next).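

In this assay, 3-(trifluoromethyl)phenyl in place of 3,4-dichlorophenyl on an amide-type nitrogen gives a number 10 percentage points lower from compound 3 to compound 4 (within the scatter), so these two aryl groups cannot be told apart here, and bringing back a trifluoromethyl is not enough on its own to reach the effect of compound 1 or compound 2. The second group on this ring can matter a great deal: hydrogen in place of trifluoromethyl gives a number 62 percentage points higher from compound 2 to compound 4 (beyond the scatter), and hydrogen in place of chloro gives a number 30 percentage points higher from compound 1 to compound 4 (beyond the scatter), although compound 3 goes against any simple rule that a further group always brings a lower number, as its 3,4-dichlorophenyl stays within the scatter of compound 4. Nothing available explains why these ring changes have the sizes they do.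

The compounds shown leave open what a plain phenyl, or an aryl ring carrying a nitrile, a methoxy or a fluoro group, would give at this place. With one concentration and one cell line, they also leave open whether these compounds would show a stronger or weaker effect relative to one another at other concentrations and whether the order holds in other cells.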